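Methyl to Hydrogen on the Aryl Ether of Compound 2

This account rests on a few compounds, and the source may have more. Where it says the series, first, only, none or still open, it means among the compounds named here.

Measured so far:
compound 1, `COc1cc(C)cc(-c2c(-c3ccnc(-c4ccc(N(C)C)cc4)c3)cnn2CC#N)c1`, 99%
compound 2, `COc1cc(C)cc(-c2nn(CC#N)cc2-c2ccnc(-c3ccc(N(C)C)cc3)c2)c1`, 109%
compound 3, `COc1cc(C)cc(-c2nn(CC#N)cc2-c2ccc(-c3cccc(C(C)=O)c3)nc2)c1`, 99%

In a functional assay on TK-10 cells (Homo sapiens) for cytotoxicity, read by sulforhodamine B assay, with a stated time of 48 h, tested at 0.001 uM (a higher number here means a weaker effect of the compound at the concentration tested, a lower number a stronger effect), compound 1 gives 99%, compound 2 gives 109% and compound 3 gives 99%. The number for compound 2 differs from that of compound 1 and from that of compound 3 by no more than the scatter of the method, so the three compounds cannot be told apart on these readings; each leaves the cells essentially untouched at the concentration tested.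

Compound 4, `Cc1cc(O)cc(-c2nn(CC#N)cc2-c2ccnc(-c3ccc(N(C)C)cc3)c2)c1`, has not yet been measured. It differs from compound 2 in one place:
hydrogen in place of methyl on an oxygen on an aromatic ring

Among the compounds with values here, no step between measured compounds is available to guide the expectation. Given that compound 1, compound 2 and compound 3 all give numbers close to full cell survival in this assay, no step beyond the scatter is expected in either direction; the expected step is a number 9 percentage points lower from compound 2 to compound 4 (within the scatter). Compound 4 is therefore estimated at 100%, within a range from 88% to 112%.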

Compound 4, a percentage reported as activity, at one concentration (the size of the read-out at that concentration, not a potency): 105%
For compound 4 the middle estimate is 5 percentage points below the measured one, and the stated range covers the measured number.
By their numbers in this assay, from the lowest: compounds 1, 3, 4 and 2 (each within the scatter of the next).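

In this assay, within the data shown here, the methoxy to hydroxy change gives the first reading at this oxygen, as compounds 1, 2 and 3 all carry the methoxy group; the step is a number 4 percentage points lower from compound 2 to compound 4 (within the scatter). Removing the methyl from the 3-methoxy-5-methylphenyl group and exposing the hydroxy therefore produces no detectable change at this single concentration, and compound 4 at 105% cannot be told apart from compound 2. No supporting evidence bears on this result.

The compounds shown leave open whether an ethyl group on this oxygen, or an amine in its place, would shift the reading. Since all four compounds leave the cells essentially untouched at this concentration, they also leave open whether methoxy and hydroxy differ where the cells respond at all.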